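The compounds below may be only part of what the source reports. "The series", "measured", "known", "first", "only" and "open" are said of these compounds alone.

Among the three compounds already measured in an assay on isolated protein for inhibition of ubiquitin carboxyl-terminal hydrolase 7 (Homo sapiens), read by fluorescence, with stated times of 30 min and 1 h (a lower number here means a stronger inhibitor, a higher number a weaker inhibitor), compound 1 `O=C([C@H]1Cc2cc(Cl)cc(-c3ccnc4ccsc34)c2O1)N1CCNCC1` gives 90 nM, which places it second highest of the three numbers. Compound 2 `O=C(C1Cc2cc(Cl)cc(-c3ccnc4[nH]ccc34)c2O1)N1CCNCC1` gives 930 nM in this assay, a higher number than compound 1 by a margin beyond the usual scatter. Compound 3 `Cc1cc(Cl)cc(-c2ccnc3cc(CN4C(=O)C5C(C4=O)C5(C)C)sc23)c1OC1CCCNC1` gives 2.4 nM, a lower number than compound 1, again beyond the scatter. Compound 3 carries a substituent on an aromatic carbon of a five-membered aromatic ring with one sulfur, but it also differs from compound 1 elsewhere, so its number offers only a loose hint.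

Compound 4 `O=C([C@H]1Cc2cc(Cl)cc(-c3ccnc4cc(C(O)(CO)CCl)sc34)c2O1)N1CCNCC1` is compound 1 with 1-(chloromethyl)-1,2-dihydroxyethyl in place of hydrogen on an aromatic carbon. Among the compounds with values here, no single step of this kind between measured compounds exists, so the expectation rests on the hint from compound 3 and the new group itself. The expected step from compound 1 to compound 4, a 2.3-fold lower number from compound 1 to compound 4 (0.35 log units; beyond the scatter), is modest and toward a lower number, near the edge of the scatter. For compound 4 the estimated value in this assay is 40 nM, within a range from 10 nM to 150 nM.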

Compound 4, half-maximal inhibitory concentration: 9 nM
Compound 4: the middle estimate sits 4.4-fold (0.65 log units) above what was measured; the whole stated range lies above it.
By their numbers in this assay, from the lowest: compound 3; then compound 4; then compound 1; then compound 2.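

Within the data shown here, replacing hydrogen with 1-(chloromethyl)-1,2-dihydroxyethyl on an aromatic carbon next to the ring sulfur gives a 10-fold lower number from compound 1 to compound 4 (1.00 log units; beyond the scatter) in this assay and is the only change here made at this position alone. Compound 3 offered only a loose hint, as it also differs from compound 1 elsewhere, whereas this single change shows that this position tolerates a branched group of this size and that the number improves with it. No available evidence explains the drop.

The compounds shown leave open which part of the new group matters, since they do not separate its two hydroxyl groups from its chlorine. A plain hydroxymethyl on this carbon, or an aminomethyl in place of the chloromethyl branch, would help to pull these parts apart.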